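Compound 2 to compound 3: phenethyl for 4-bromophenyl

A few compounds are considered here, and "the series" means these few. Any claim that something is new, unique, unknown or untested is made for them only; others in the source may bear on it.

In an ADME assay on MDBK cells (Bos taurus) for cytotoxicity (a higher number here means that more compound is tolerated, a lower number that less compound is tolerated), compound 1 `Clc1ccccc1Cn1ccc2nc(-c3ccccc3)nc-2c1` reads > 100000 nM, which is a limit of the assay. Among the measured compounds shown here, compound 2 `Brc1ccc(Cn2ccc3nc(-c4ccccc4)nc-3c2)cc1` gives 83000 nM, the only actual number so far. Compound 3 `c1ccc(CCCn2ccc3nc(-c4ccccc4)nc-3c2)cc1` carries phenethyl in place of 4-bromophenyl on a saturated chain carbon bound to an aromatic nitrogen. For the measured compounds named here, one measured step bears on this change, made at the same place: an at least 1.2-fold lower number from compound 1 to compound 2 (0.08 log units; that floor lies within the scatter). On that step alone, no change beyond the scatter is expected in this assay. The expected step is a 1.4-fold lower number from compound 2 to compound 3 (0.14 log units; within the scatter). Compound 3 is estimated at 60000 nM, with an expected range of 25000 nM to 100000 nM.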

Compound 3, half-maximal cytotoxic concentration: > 100000 nM
Compound 3 ended at the assay's limit; the forecaster's own chance of this, stated with the estimate: 25%; at least 1.6-fold (0.22 log units) between middle value and limit.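

In this assay, compound 3 gives > 100000 nM, which is a limit of the assay and not a number. From the compounds shown here alone, with phenethyl, a group of carbon only, in place of 4-bromophenyl on a saturated chain carbon bound to an aromatic nitrogen, the reading is an at least 1.2-fold higher number from compound 2 to compound 3 (0.08 log units; that floor lies within the scatter), so the change shows no loss of tolerance, and its true size stays unknown. The step between the two compounds that both stand at the limit cannot be read.

Going by these compounds, whether an amine or a carboxylic acid on this chain would lower the number remains open. Most of the series gives no actual number for ranking: the limit of > 100000 nM in this assay, at which 2 of the 3 values shown sit.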